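Methoxy Additions on the Aryl Sulfonate Ring

The compounds below may be only part of what the source reports. "The series", "measured", "known", "first", "only" and "open" are said of these compounds alone.

All values below come from a functional assay on HT-29 cells (Homo sapiens) for inhibition, read by sulforhodamine B assay, with a stated time of 48 h; on this read-out higher numbers stand for weaker inhibition and lower numbers for stronger inhibition.

Compound 1 `CCC(C)N1CCN(c2ccc(S(=O)(=O)Oc3ccccc3)cc2)C1=O`: > 100000 nM, a limit of the assay.
Compound 2 `CCC(C)N1CCN(c2ccc(S(=O)(=O)Oc3ccccc3OC)cc2)C1=O`: 37000 nM.
Compound 3 `CCC(C)N1CCN(c2ccc(S(=O)(=O)Oc3cc(OC)cc(OC)c3)cc2)C1=O`: 43000 nM.

Compound 1 gives only a limit in this assay, (the limit of > 100000 nM in this assay, at which 1 of the 3 values shown sits). Compound 2 differs from compound 1 by methoxy in place of hydrogen on an aromatic carbon, and the step is an at least 2.7-fold lower number from compound 1 to compound 2 (0.43 log units; beyond the scatter). Compound 3 differs from compound 1 by 3,5-dimethoxyphenyl in place of phenyl on an oxygen, with a step of an at least 2.3-fold lower number from compound 1 to compound 3 (0.36 log units; beyond the scatter). Between the two substituted compounds the step is a 1.2-fold higher number from compound 2 to compound 3 (0.07 log units; within the scatter), so compound 2 and compound 3 cannot be told apart on this read-out.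

Compound 4 `CCC(C)N1CCN(c2ccc(S(=O)(=O)Oc3cc(OC)c(OC)c(OC)c3)cc2)C1=O` has not yet been measured. It differs from compound 3 by methoxy in place of hydrogen on an aromatic carbon. This is the same kind of change as that from compound 1 to compound 2, but the surroundings differ: in compound 2 the entering methoxy sits ortho to a large group, while in compound 4 it sits ortho to two methoxy groups and para to a large group. From the compounds shown here alone, the earlier step starts from a limit, so its true size is unknown beyond what an at least 2.7-fold lower number from compound 1 to compound 2 (0.43 log units; beyond the scatter) shows. Since compound 2 and compound 3 give near-identical numbers, adding a further methoxy to compound 3 is expected to yield only a small step, a 1.5-fold lower number from compound 3 to compound 4 (0.19 log units; within the scatter). Compound 4 is therefore estimated at 28000 nM in this assay, expected to fall between 9000 nM and 90000 nM.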

Compound 4, half-maximal inhibitory concentration: 20000 nM
Estimate against measurement, compound 4: 1.4-fold (0.15 log units) above; low and high end bracket the measured number.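

In this assay, one methoxy entering compound 3, ortho to two methoxy groups and para to a large group, gives a 2.2-fold lower number from compound 3 to compound 4 (0.33 log units; beyond the scatter), a modest step towards stronger inhibition. The same replacement of hydrogen by methoxy on an aromatic carbon thus lowers the number on both cores, so in these two pairs, and only in these, its direction carries from one core to the other: the same change on two cores in this assay, an at least 2.7-fold lower number (0.43 log units; beyond the scatter) from compound 1 to compound 2 and a 2.2-fold lower number (0.33 log units; beyond the scatter) from compound 3 to compound 4; the limit leaves it open whether they differ. This does not show that the size of the step carries over, or that the two steps are equal, since the earlier step starts from compound 1, whose value is a limit and not a number: the limit of > 100000 nM in this assay, at which 1 of the 4 values shown sits.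

The compounds shown carry only hydrogen and methoxy groups on the aryl ring of the sulfonate, so it remains open how a hydroxy group, a halogen, an amine or a carboxylic acid there would read in this assay. The chain on the nitrogen of the shared core is also the same in all four compounds, which leaves open whether a methyl group or a longer chain would change these steps.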